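This account rests on a few compounds, and the source may have more. Where it says the series, first, only, none or still open, it means among the compounds named here.

Compound 1 `Cc1cc(=O)oc2cc(Sc3cccc(Cl)[n+]3[O-])ccc12` in a functional assay on KBVIN cells (Homo sapiens) for antiproliferative activity, read by sulforhodamine B assay, with a stated time of 72 h (on this read-out lower numbers stand for stronger inhibition of growth and higher numbers for weaker inhibition of growth), gives 24500 nM. Compound 2 `Cc1cc(=O)oc2cc(SC3CCOC3=O)ccc12` gives > 36100 nM, which is a limit of this assay rather than a number. Compound 3 `Cc1cc(=O)oc2cc(SCc3ccccn3)ccc12` gives > 35200 nM, also a limit of this assay.

Compound 3 therefore stands at the limit of > 35200 nM in this assay, at which 1 of the 3 values shown sits, and one further value among the three is a limit as well, so its position cannot be placed any finer than that. Compound 4 `Cc1cc(=O)oc2cc(SCc3cccnc3)ccc12` has not been measured. It differs from compound 3 by pyridin-3-yl in place of pyridin-2-yl on a saturated chain carbon bound to a sulfur. Going by the values given here, no measured pair shows the effect of such a change, so no step beyond the usual scatter is expected, and compound 4 is expected to sit close to its parent, with a step that the limit leaves unreadable from compound 3 to compound 4. The estimate for compound 4 is 45000 nM, in the range 15000 nM to 135000 nM.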

Compound 4, concentration for 50% growth inhibition: > 35200 nM
Compound 4: only a limit was reported; the forecaster's own chance of this, stated with the estimate: 75%; the middle value does not contradict the limit.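

Compound 3 gives > 35200 nM, which is a limit. Compound 4 gives > 35200 nM, also a limit, so no step can be read between compound 3 and compound 4. As far as these compounds go, whether pyridin-3-yl and pyridin-2-yl differ in their effect on growth remains open.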